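Methylamino in place of methyl on a urea-linked fused core

This account rests on a few compounds, and the source may have more. Where it says the series, first, only, none or still open, it means among the compounds named here.

Compound 1 `O=C(Nc1ccc(-n2ncc3c(C(F)(F)F)cccc32)cc1)Nc1ccc(Cl)c(C(F)(F)F)c1`: 3000 nM
Compound 2 `O=C(Nc1ccc(-n2ncc3c(F)cccc32)cc1)Nc1ccc(Cl)c(C(F)(F)F)c1`: 3800 nM
Compound 3 `Cc1cccc2c1cnn2-c1ccc(NC(=O)Nc2ccc(Cl)c(C(F)(F)F)c2)cc1`: 5500 nM

Three compounds share a core and differ only in one group on an aromatic carbon of the fused ring system. In a functional assay on A549 cells (Homo sapiens) for cytotoxicity, read by MTT assay, with a stated time of 72 h (on this read-out lower numbers stand for stronger inhibition and higher numbers for weaker inhibition), compound 1 gives 3000 nM, compound 2 gives 3800 nM and compound 3 gives 5500 nM. Compound 3 sits at the high end of the three, but the step of a 1.4-fold higher number from compound 2 to compound 3 (0.16 log units; within the scatter) and the step of a 1.8-fold higher number from compound 1 to compound 3 (0.26 log units; within the scatter) both lie within the scatter, as does a 1.3-fold higher number from compound 1 to compound 2 (0.10 log units; within the scatter). Swapping trifluoromethyl, fluoro and methyl at this carbon therefore changed nothing that can be told apart from repeat measurements.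

Compound 4 `CNc1cccc2c1cnn2-c1ccc(NC(=O)Nc2ccc(Cl)c(C(F)(F)F)c2)cc1` is not yet measured. It differs from compound 3 by methylamino in place of methyl on an aromatic carbon. All three measured steps concern the same carbon and were within the scatter, so no step beyond the scatter is expected in this assay for compound 4 either, with the estimated step of a 1.1-fold lower number from compound 3 to compound 4 (0.04 log units; within the scatter). Compound 4 is expected to give 5000 nM, with a range from 2000 nM to 12000 nM.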

Compound 4, half-maximal inhibitory concentration: 4900 nM
Compound 4: the middle estimate sits 1.0-fold (0.01 log units) above what was measured; measured number inside the range.
By their numbers in this assay, from the lowest: compounds 1, 2, 4 and 3 (each within the scatter of the next).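

Of the four groups at this aromatic carbon, only methylamino brings a nitrogen, and with it a hydrogen-bond donor and a hydrogen-bond acceptor that methyl lacks, yet in this assay swapping methyl for it gives only a small step (a 1.1-fold lower number from compound 3 to compound 4 (0.05 log units; within the scatter)) that cannot be told apart from repeat measurements. The comparisons with the other two groups (a 1.3-fold higher number from compound 2 to compound 4 (0.11 log units; within the scatter) and a 1.6-fold higher number from compound 1 to compound 4 (0.21 log units; within the scatter)) also stay inside the scatter, so adding a group of this different kind to trifluoromethyl, fluoro and methyl still leaves all four compounds indistinguishable on this read-out. Nothing measured here bears on why the numbers stay so close.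

On these data alone, whether a carboxylic acid, a dimethylamino group or a longer chain on this carbon would move the number beyond the scatter remains open. So does whether these four compounds would also stay this close on other cell types.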